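Replacing a large ring by nitro on the shared core

The source may report more compounds than this note shows. Statements on the series, on what has been measured and on what is new or still open speak of the compounds shown alone.

Measured compounds in an assay on CHO cells for antagonist activity at transient receptor potential cation channel subfamily V member 1 (Homo sapiens), read by FLIPR; on this read-out lower numbers stand for stronger inhibition and higher numbers for weaker inhibition:
- compound 1, `CC(C(=O)NCc1ccc(C(F)(F)F)cc1N1CCC(C)(C)CC1)c1ccc(NS(C)(=O)=O)c(F)c1`, gives 1.3 nM
- compound 2, `CC(C(=O)NCc1ccc(C(F)(F)F)cc1OCc1ccc(F)cc1)c1ccc(NS(C)(=O)=O)c(F)c1`, gives 0.5 nM
- compound 3, `C[C@@H](C(=O)NCc1ccc(C(F)(F)F)cc1SC1CCCCC1)c1ccc(NS(C)(=O)=O)c(F)c1`, gives 13.9 nM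

Compound 1 stands second highest of these three numbers; its nearest neighbour is compound 2, and compound 3 lies furthest from it. The change that is followed here leads to compound 4, `CC(C(=O)NCc1ccc(C(F)(F)F)cc1[N+](=O)[O-])c1ccc(NS(C)(=O)=O)c(F)c1`, which is not yet measured. Compared with compound 1, (nitro in place of 4,4-dimethylpiperidin-1-yl on an aromatic carbon). Among the compounds with values here, the only measured step at the same position is a 2.6-fold lower number from compound 1 to compound 2 (0.41 log units; beyond the scatter), where one large group replaced another and the number moved modestly. Within the data shown here, compound 3 carries a different large group there and gives a clearly higher number than compound 1, but no single-change step links the two. Nothing measured shows what a small group such as nitro does at this place, so the expected step of a 15-fold higher number from compound 1 to compound 4 (1.19 log units; beyond the scatter) is uncertain and is estimated to raise the number. Compound 4 is therefore expected to give about 20 nM in this assay, within a range from 3 nM to 150 nM.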

Compound 4, inhibition constant: "not active" (no number reported)
For compound 4 the study gives words and no number, and the estimate cannot be compared.
By their numbers in this assay, from the lowest: compound 2; then compound 1; then compound 3.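

Within the data shown here, compound 4 is reported only in words, as not active, so no step from compound 1 to compound 4 can be read. The compounds shown leave open how a small group at this place compares with the large groups of compound 1, compound 2 and compound 3. No supporting measurement bears on this result.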